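Removing the triazole: a terminal alkyne in its place

This account rests on a few compounds, and the source may have more. Where it says the series, first, only, none or still open, it means among the compounds named here.

Of the compounds shown here, two with the same core have been measured in an assay on CHO cells for displacement of a labelled ligand from adenosine receptor A3 (Homo sapiens), read by scintillation counting; on this read-out lower numbers stand for stronger inhibition and higher numbers for weaker inhibition. Compound 1 `CNC(=O)[C@@]12C[C@@H]1[C@@H](n1cnc3c(NCc4cccc(Cl)c4)nc(C#CCCCCc4cn(CCCCN)nn4)nc31)[C@H](O)[C@@H]2O` carries a triazole ring on its chain bearing a 2-aminoethyl group, and in this assay compound 1 gives 47 nM. Compound 2 `CNC(=O)[C@@]12C[C@@H]1[C@@H](n1cnc3c(NCc4cccc(Cl)c4)nc(C#CCCCCc4cn(CCNC(C)=O)nn4)nc31)[C@H](O)[C@@H]2O` differs only in that the amine is capped as an acetamide, and in this assay compound 2 gives 22.3 nM. Within the data shown here, the one step between them, a 2.1-fold lower number from compound 1 to compound 2 (0.32 log units; beyond the scatter), is therefore a modest one, and compound 2 stands as the lower of the two numbers.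

Compound 3 `C#CCCCCC#Cc1nc(NCc2cccc(Cl)c2)c2ncn([C@H]3[C@H](O)[C@H](O)[C@]4(C(=O)NC)C[C@H]34)c2n1` is the one not yet measured. Relative to compound 2 the change is ethynyl in place of 1-(2-acetamidoethyl)-1H-1,2,3-triazol-4-yl on a saturated chain carbon, four bonds along the chain from a triple-bonded carbon: the whole triazole with its acetamidoethyl arm is gone and the chain ends in a bare triple bond. Among the measured compounds shown here, no measured step speaks to this change; the step from compound 1 to compound 2 only altered the arm on the triazole, not the ring itself. The expectation is therefore cautious: compound 3 is estimated at 40 nM, with a plausible range from 10 nM to 160 nM, which would mean a step of a 1.8-fold higher number from compound 2 to compound 3 (0.25 log units; within the scatter), expected to be small or within the scatter.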

Compound 3, inhibition constant: 29.4 nM
Compound 3: middle estimate off by 1.4-fold (0.13 log units), on the high side; low and high end bracket the measured number.
By their numbers in this assay, from the lowest: compounds 2, 3 and 1 (each within the scatter of the next, the first and the last beyond it).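

Cutting the chain back so that it ends in ethynyl removes the whole 1-(2-acetamidoethyl)-1H-1,2,3-triazol-4-yl group, 11 heavy atoms including a five-membered aromatic ring, yet in this assay the result is a 1.3-fold higher number from compound 2 to compound 3 (0.12 log units; within the scatter) and so does not separate the two compounds. Losing the 1-(4-aminobutyl)-1H-1,2,3-triazol-4-yl group gives the same picture, with a 1.6-fold lower number from compound 1 to compound 3 (0.20 log units; within the scatter) in this assay as well, so among these three compounds neither the triazole ring nor either of its arms is needed for a number in this range, a point the earlier pair could not address because both of its members carry the ring. The data shown hold nothing that explains why the number stays in this range after so large a removal.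

The compounds shown leave open whether a longer chain ending in ethynyl, or a chain ending in a plain methyl group instead of the triple bond, would keep the number in the same range. They also leave open how a carboxylic acid at the end of the triazole arm would compare with the amine of compound 1 and the acetamide of compound 2.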